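A few compounds are considered here, and "the series" means these few. Any claim that something is new, unique, unknown or untested is made for them only; others in the source may bear on it.

Series notes. Compound 1 `CC(C)c1onc(-c2c(Cl)cccc2Cl)c1COc1ccc(-c2nc3ccc(C(=O)O)cc3n2CC(C)(C)C)cc1` and compound 2 `CC(C)c1onc(-c2c(Cl)cccc2Cl)c1COc1ccc(-c2nc3ccc(C(=O)O)cc3n2C2CC2)cc1` share one core and differ only in the group on the aromatic nitrogen. In an assay on Huh-7 cells for agonist activity at Bile acid receptor (Homo sapiens), read by a luciferase reporter (a lower number here means that less compound is needed, a higher number that more compound is needed for the effect), compound 1 gives 13 nM, and compound 2 gives 16.5 nM. The step of a 1.3-fold higher number from compound 1 to compound 2 (0.10 log units; within the scatter), cyclopropyl in place of neopentyl on the aromatic nitrogen, lies within the scatter. Going by the values given here, compound 2 thus holds the highest of the two numbers so far, with compound 1 the nearest and within the scatter of it, so no order between the two can be read from these data.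

Compound 3 `CCCC(CCC)n1c(-c2ccc(OCc3c(-c4c(Cl)cccc4Cl)noc3C(C)C)cc2)nc2ccc(C(=O)O)cc21` is next. Its change from compound 2 is 1-propylbutyl in place of cyclopropyl on an aromatic nitrogen. Among the compounds with values here, the only measured step bearing on this position is a 1.3-fold higher number from compound 1 to compound 2 (0.10 log units; within the scatter), which exchanged one group on the same nitrogen for another without moving the number beyond the scatter. On that basis the step of a 1.0-fold lower number from compound 2 to compound 3 (0.01 log units; within the scatter) is expected to stay within the scatter, with no direction preferred. A single prior step is a thin basis, and the entering chain is unlike either group measured so far, so the range is kept wide. For compound 3 the estimate in this assay is 16 nM, with a range from 5 nM to 50 nM.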

Compound 3, half-maximal effective concentration: 1.8 nM
The estimate for compound 3 lay 8.9-fold (0.95 log units) above the measured number; the measured number lies below the stated range.
By their numbers in this assay, from the lowest: compound 3; then compounds 1 and 2 (each within the scatter of the next).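

The group on the aromatic nitrogen is not neutral in this assay: with 1-propylbutyl entering, the series shows a 9.2-fold lower number from compound 2 to compound 3 (0.96 log units; beyond the scatter) and a 7.2-fold lower number from compound 1 to compound 3 (0.86 log units; beyond the scatter), both beyond the scatter, whereas the earlier exchange of neopentyl and cyclopropyl gave only a 1.3-fold higher number from compound 1 to compound 2 (0.10 log units; within the scatter), within the scatter. The agreement of the two new steps shows that the lower number of compound 3 does not depend on which of the two earlier groups serves as the reference, and that the flat result for compounds 1 and 2 did not extend to every group at this nitrogen. Nothing available here accounts for the shift at this position.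

The step from cyclopropyl to 1-propylbutyl changes the carbon count, removes the ring and introduces the two propyl arms all at once, so these compounds cannot assign the shift to any one of those changes. Open questions are whether a shorter branched group such as 1-ethylpropyl, a ring such as cyclohexyl or a longer unbranched chain such as n-heptyl would keep the number of compound 3, and whether an ether oxygen or an amine within the chain would be tolerated.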